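Chloro for methyl on the phenoxy ring of compound 3

This account rests on a few compounds, and the source may have more. Where it says the series, first, only, none or still open, it means among the compounds named here.

Measured so far in a functional assay on the whole organism (strain Wistar albino) for inhibition, with Rattus norvegicus as the target, read by paw edema, at a dose of 10 mg/kg by the oral route; on this read-out higher numbers stand for more inhibition at the one dose given (going by the name of the read-out) and lower numbers for less inhibition:
- compound 1, `Cc1ccccc1OCc1ccccc1-c1nc(CN2CCN(C(c3ccccc3)c3ccc(Cl)cc3)CC2)cs1`, gives 63.2%
- compound 2, `Cc1ccccc1OCc1ccccc1-c1nc(CN2CCN(C(c3ccccc3)c3ccccc3)CC2)cs1`, gives 64%
- compound 3, `Cc1ccc(OCc2ccccc2-c2nc(-c3cc(Cl)sc3S(N)(=O)=O)cs2)cc1`, gives 68.7%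

Compound 3 has the highest of the three numbers, but its margin over compound 2 and over compound 1 lies within the scatter of repeated measurements, so the three compounds cannot be told apart on this evidence.

Compound 4, `NS(=O)(=O)c1sc(Cl)cc1-c1csc(-c2ccccc2COc2ccc(Cl)cc2)n1`, differs from compound 3 in one place: chloro in place of methyl on an aromatic carbon. It is the 4-methylphenoxy group of compound 3 that becomes a 4-chlorophenoxy group in compound 4.

Among the measured compounds shown here, only one measured step involves a chloro group on an aromatic carbon, and it is not the same change: going a number 0.8 percentage points higher from compound 1 to compound 2 (within the scatter) swapped chloro for hydrogen on a different ring and stayed within the scatter. For the measured compounds named here, no measured pair exchanges chloro for methyl, so the expectation for compound 4 leans on that single step and on the small size of the change.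

Compound 4 is therefore expected to stay close to compound 3, with a shift of a number 1.7 percentage points lower from compound 3 to compound 4 (within the scatter) and no move beyond the scatter. Compound 4 is estimated at 67%, within a range from 52% to 80%.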

Compound 4, a percentage reported as inhibition, in the whole organism at one dose (the size of the read-out at that dose, not a potency): 76.4%
Beside the measured number, compound 4's estimate is 9.4 percentage points below it, within the range that was stated.
By their numbers in this assay, from the lowest: compounds 1, 2, 3 and 4 (each within the scatter of the next, the first and the last beyond it).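

Among the compounds shown here, compound 3 and compound 4 form the first pair here that differs on the phenoxy ring, and in this assay the exchange of 4-methylphenoxy for 4-chlorophenoxy gives a number 7.7 percentage points higher from compound 3 to compound 4 (within the scatter), so this position accepts either group without a difference that can be told from the scatter. The earlier step, which exchanged chloro for hydrogen on a different ring, also stayed within the scatter, so neither of the two single-place changes shown separates its pair on this read-out, although two steps are too few to establish a general pattern. Nothing available explains the result of the exchange between methyl and chloro at this position.

The compounds shown leave open whether an unsubstituted phenoxy ring, or a methoxy, trifluoromethyl or carboxylic acid group in the same place, would give a number that stands clear of the scatter. They also leave open whether compound 3 and compound 4 would separate at other doses, since a reading at one dose shows the size of the effect at that dose and not potency.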